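Fluoro for Methyl on the Aryl Ring of Compound 3

A few compounds are considered here, and "the series" means these few. Any claim that something is new, unique, unknown or untested is made for them only; others in the source may bear on it.

Of the compounds shown here, three built on one shared core have been measured in a functional assay on CHO cells for agonist activity at Free fatty acid receptor 1 (Homo sapiens), read by FLIPR and calcium flux, tested at 100 nM; on this read-out lower numbers stand for a weaker effect and higher numbers for a stronger effect at the one concentration tested. Compound 1 `O=C(O)CC1COc2cc(OCc3ncc(-c4ccccc4)s3)ccc21` gives 5.26% in this assay. Compound 2 `Cc1nc(-c2ccccc2)oc1COc1ccc2c(c1)OCC2CC(=O)O` gives 7.15% in this assay. Compound 3 `Cc1cccc(-c2nc(C)c(COc3ccc4c(c3)OCC4CC(=O)O)s2)c1` gives 47.2% in this assay, the highest of the three numbers; its nearest neighbour is compound 2, whose number lies lower by more than the usual scatter, and compound 1 lies further below still, also beyond the scatter.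

Compound 4 `Cc1nc(-c2cccc(F)c2)sc1COc1ccc2c(c1)OCC2CC(=O)O` has not yet been measured in this assay. It differs from compound 3 in a single place: fluoro in place of methyl on an aromatic carbon. Cut one bond further out, the same change reads 3-methylphenyl to 3-fluorophenyl. Among the measured compounds shown here, no pair of measured compounds shows this exchange, so no measured step can be carried over, and the expectation rests on compound 3 alone. Compound 4 is expected to give about 35% in this assay, with a range from 15% to 55%. The step from compound 3 to compound 4 is estimated at a number 12.2 percentage points lower from compound 3 to compound 4 (beyond the scatter), a small fall close to the edge of the scatter, with a real chance that the two numbers end up indistinguishable.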

Compound 4, a percentage reported as activity, at one concentration (the size of the read-out at that concentration, not a potency): 56.9%
The estimate for compound 4 lay 21.9 percentage points below the measured number; the measured number lies above the stated range.
By their numbers in this assay, from the lowest: compounds 1 and 2 (each within the scatter of the next); then compounds 3 and 4 (each within the scatter of the next).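

In this assay, among the compounds shown here, the exchange of methyl for fluoro on an aromatic carbon, meta to a large group, supplies the one step available at this position: a number 9.7 percentage points higher from compound 3 to compound 4 (within the scatter). The earlier compounds shown here could not show this, as none of them differed from another in one place; now it is clear that the methyl group of compound 3 is not needed to keep this read-out at the one concentration tested, since compound 4, which carries fluoro there, cannot be told apart from compound 3. Nothing at hand bears on why the 3-methylphenyl and 3-fluorophenyl compounds read alike, so the result stands as an observation without an explanation.

What the compounds shown leave open is how far this tolerance extends, for instance whether a chloro, methoxy, trifluoromethyl or nitrile group at the same carbon, or an unsubstituted phenyl ring on this same core, would read alike. Going by these compounds, a reading at one concentration is also not a potency, so it remains open whether compound 3 and compound 4 would still match across a range of concentrations.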